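The source may report more compounds than this note shows. Statements on the series, on what has been measured and on what is new or still open speak of the compounds shown alone.

Measured compounds in a functional assay on HEK293 cells for agonist activity at probable G-protein coupled receptor 27 (Homo sapiens), read by a luciferase reporter and beta-arrestin recruitment, with a stated time of 10 min; a lower number here means that less compound is needed, a higher number that more compound is needed for the effect:
- compound 3, `Cc1ccccc1NS(=O)(=O)c1ccc(NC(=O)c2ccc(Cl)cc2Cl)cc1`: 1230 nM
- compound 1, `O=C(Nc1ccc(S(=O)(=O)Nc2ccccc2)cc1)c1ccc(Cl)nc1F`: 2290 nM
- compound 2, `Cc1ccc(NS(=O)(=O)c2ccc(NC(=O)c3ccc(Cl)cc3Cl)cc2)cc1`: > 100000 nM, a limit of this assay rather than a number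

Compound 3 and compound 1 give numbers that sit within the usual scatter of each other, so neither can be set above the other. Of compound 2 only a limit is known (the limit of > 100000 nM in this assay, at which 1 of the 3 values shown sits).

Among the compounds with values here, the one step that can be measured runs an at least 81-fold lower number from compound 2 to compound 3 (1.91 log units; beyond the scatter), which shows that the substitution pattern on the sulfonamide nitrogen aryl group is decisive, while the acyl part shared by compound 2 and compound 3 stays the same.

Compound 4, `O=C(Nc1ccc(S(=O)(=O)Nc2ncccn2)cc1)c1ccc(Cl)cc1Cl`, is not yet measured. It differs from compound 3 by pyrimidin-2-yl in place of 2-methylphenyl on a sulfonamide nitrogen. Within the data shown here, no measured compound in the set carries a heteroaryl on the sulfonamide nitrogen, so there is no step that directly bears on this exchange; the only related step, that from compound 2 to compound 3, concerns the position of a methyl group and not a change of the ring itself. Since that step was large, a sizeable move in this assay is expected, and the direction is taken to be towards a higher number, the pyrimidin-2-yl ring lying far from the 2-methylphenyl that gave the lowest number here.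

For compound 4 the expected value in this assay is 8000 nM, within 1500 nM to 50000 nM, which is estimated to correspond to a 6.5-fold higher number from compound 3 to compound 4 (0.81 log units; beyond the scatter).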

Compound 4, half-maximal effective concentration: > 100000 nM
Compound 4 ended at the assay's limit; the forecaster's own chance of this, stated with the estimate: 25%; at least 12-fold (1.09 log units) between middle value and limit.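

Replacing the ring itself on the sulfonamide nitrogen, and not only shifting a methyl group on it, has a large effect at this position: pyrimidin-2-yl in place of 2-methylphenyl gives an at least 81-fold higher number from compound 3 to compound 4 (1.91 log units; beyond the scatter) in this assay. In this assay compound 4 gives > 100000 nM, which is a limit and not a number. Among the compounds with the acyl part of compound 3, 2-methylphenyl is thus the only group on this nitrogen that gives a number, while 4-methylphenyl in compound 2 and pyrimidin-2-yl in compound 4 both end at the limit: the limit of > 100000 nM in this assay, at which 2 of the 4 values shown sit.

The step between compound 2 and compound 4 cannot be read, since both are limits. From the compounds shown here alone, compound 4 both loses the methyl group and brings in two ring nitrogens, so it remains open which of the two changes carries the step, and a pyridin-2-yl or a 2-chlorophenyl on the sulfonamide nitrogen would begin to separate them.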